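Three Side Chains Measured, a Fourth Awaiting Its Number

The source may hold more compounds than are shown below. What is called first, only, known or untested is meant among the compounds shown, and "the series" means these compounds.

Compound 1, `CCCCn1cc(Cn2nc(N)c3c(C(F)(F)F)cc(-c4ccccc4)nc32)nn1`: 46.1 ug/mL
Compound 2, `CCCCCCCCCCn1cc(Cn2nc(N)c3c(C(F)(F)F)cc(-c4ccccc4)nc32)nn1`: 48.7 ug/mL
Compound 3, `Nc1nn(Cc2cn(CC(=O)Nc3ccc(F)cc3)nn2)c2nc(-c3ccccc3)cc(C(F)(F)F)c12`: 49.6 ug/mL

The three compounds share one core and differ only in the group carried on the saturated chain carbon bound to an aromatic nitrogen. In a functional assay on THP-1 cells (Homo sapiens) for cytotoxicity, read by MTT assay, with a stated time of 24 h (a lower number here means a stronger inhibitor, a higher number a weaker inhibitor), compound 1 has the lowest of the three numbers, but its gaps to the others are within the scatter: a 1.1-fold higher number from compound 1 to compound 2 (0.02 log units; within the scatter) and a 1.1-fold higher number from compound 1 to compound 3 (0.03 log units; within the scatter). The remaining pair behaves the same way, a 1.0-fold higher number from compound 2 to compound 3 (0.01 log units; within the scatter). Compound 4, `Cc1ccc(NC(=O)Cn2cc(Cn3nc(N)c4c(C(F)(F)F)cc(-c5ccccc5)nc43)nn2)cc1`, has not yet been measured in this assay. It differs from compound 1 in that ((4-methylphenyl)carbamoyl in place of propyl on a saturated chain carbon bound to an aromatic nitrogen). The step from compound 1 to compound 3, which also exchanges propyl for a carbamoyl group bearing a substituted phenyl at the same place, bears most directly on this change, and it stayed within the scatter; the step from compound 2 to compound 3 points the same way. Compound 4 is therefore expected to show no step beyond the scatter, a 1.0-fold higher number from compound 1 to compound 4 (0.02 log units; within the scatter). The estimated number for compound 4 is 48 ug/mL, expected to fall between 30 ug/mL and 75 ug/mL.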

Compound 4, half-maximal inhibitory concentration: 41.5 ug/mL
Compound 4: middle estimate off by 1.2-fold (0.06 log units), on the high side; the range from low to high includes it.
By their numbers in this assay, from the lowest: compounds 4, 1, 2 and 3 (each within the scatter of the next).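

With methyl in place of fluoro on an aromatic carbon, the new result gives a 1.2-fold lower number from compound 3 to compound 4 (0.08 log units; within the scatter) in this assay and adds the first change shown on the phenyl ring of the carbamoyl group itself. (4-Methylphenyl)carbamoyl in place of nonyl gives a 1.2-fold lower number from compound 2 to compound 4 (0.07 log units; within the scatter) and in place of propyl gives a 1.1-fold lower number from compound 1 to compound 4 (0.05 log units; within the scatter) and thus, in this small set, a second aryl carbamoyl group joins the butyl and decyl chains with no step beyond the scatter, leaving the four compounds without an order. Nothing on hand explains why these numbers stay so close.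

The compounds shown leave open whether a carboxylic acid or an amine at the end of this side chain would give a step beyond the scatter. They also leave open whether a chloro or methoxy group on that phenyl ring would do so.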